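Sulfonate ester series: aryl change on propyl lactam

This account rests on a few compounds, and the source may have more. Where it says the series, first, only, none or still open, it means among the compounds named here.

Measured so far:
compound 1 `Cc1ccc(OS(=O)(=O)c2ccc(N3CCN(C)C3=O)cc2)c(C)c1` — 3000 nM
compound 2 `CCN1CCN(c2ccc(S(=O)(=O)Oc3cccc(Cl)c3)cc2)C1=O` — 6800 nM
compound 3 `CCCN1CCN(c2ccc(S(=O)(=O)Oc3ccc(C)cc3C)cc2)C1=O` — 26000 nM

In a functional assay on HT-29 cells (Homo sapiens) for antiproliferative activity, read by sulforhodamine B assay, with a stated time of 48 h (a higher number here means a weaker inhibitor, a lower number a stronger inhibitor), compound 3 gives 26000 nM, the highest number of the three measured compounds; compound 2 gives 6800 nM and compound 1 gives 3000 nM. Among the measured compounds shown here, the only measured step within this set is an 8.7-fold higher number from compound 1 to compound 3 (0.94 log units; beyond the scatter), which concerns the chain on the ring nitrogen and not the aryl part.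

Compound 4 `CCCN1CCN(c2ccc(S(=O)(=O)Oc3ccc(OC)cc3)cc2)C1=O` differs from compound 3 only at the aryl on the sulfonate oxygen: 4-methoxyphenyl in place of 2,4-dimethylphenyl on an oxygen. For the measured compounds named here, no measured pair isolates a change of the aryl group alone; compound 2 and compound 3 differ in two places at once, so their values show only that the combination in compound 2 gives a lower number. Nothing therefore points to a step in either direction beyond the scatter for this assay, and the expectation is a number close to that of compound 3.

The expected step is a 1.3-fold lower number from compound 3 to compound 4 (0.11 log units; within the scatter), with compound 4 estimated at 20000 nM and a range from 6000 nM to 60000 nM.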

Compound 4, half-maximal inhibitory concentration: 16000 nM
The estimate for compound 4 lay 1.3-fold (0.10 log units) above the measured number; measured number inside the range.
By their numbers in this assay, from the lowest: compound 1; then compound 2; then compounds 4 and 3 (each within the scatter of the next).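

Among the compounds shown here, compound 3 and compound 4 form the first pair here that isolates the aryl group on the oxygen bound to the sulfonyl sulfur, and in this assay the change to 4-methoxyphenyl gives a 1.6-fold lower number from compound 3 to compound 4 (0.21 log units; within the scatter) in this series. At this position, then, the exchange of 2,4-dimethylphenyl, with 0 hydrogen-bond acceptors, for 4-methoxyphenyl, with 1, leaves the number within the scatter, although this single pair sets no trend for other aryl groups. No measured evidence bears on why these two aryl groups read alike.

On these data alone, it remains open whether an aryl group carrying a carboxylic acid or an amine would give a step beyond the scatter at this position. As far as these compounds go, it is also open whether the same exchange on the core of compound 1 would give a step of similar size.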